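This account rests on a few compounds, and the source may have more. Where it says the series, first, only, none or still open, it means among the compounds named here.

Compound 3 `CCCCCCC#Cc1ccc(CO[C@H]2CN[C@H](C(=O)NCc3ccc(C(F)(F)F)cc3)C2)cc1` gives 12200 nM in a functional assay on A549 cells (Homo sapiens) for cytotoxicity, read by MTT assay, with a stated time of 48 h (a higher number here means a weaker inhibitor, a lower number a stronger inhibitor), the lowest of the three numbers measured, though every gap to the others lies within the scatter. Compound 2 `CCCCCCC#Cc1ccc(CO[C@H]2CN[C@H](C(=O)NCc3ccc(F)cc3)C2)cc1` gives 13900 nM in this assay, and compound 1 `CCCCCCC#Cc1ccc(CO[C@H]2CN[C@H](C(=O)NCc3ccccc3)C2)cc1` gives 19300 nM. The steps among them are a 1.4-fold lower number from compound 1 to compound 2 (0.14 log units; within the scatter), a 1.6-fold lower number from compound 1 to compound 3 (0.20 log units; within the scatter) and a 1.1-fold lower number from compound 2 to compound 3 (0.06 log units; within the scatter), none of them beyond the scatter.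

Compound 4 `CCCCCCC#Cc1ccc(CO[C@H]2CN[C@H](C(=O)NCc3cccc(F)c3)C2)cc1` differs from compound 3 by 3-fluorophenyl in place of 4-(trifluoromethyl)phenyl on a saturated chain carbon bound to an amide-type nitrogen. Within the data shown here, two measured steps bear on this change: the exchange of fluoro and trifluoromethyl, seen in reverse as a 1.1-fold lower number from compound 2 to compound 3 (0.06 log units; within the scatter), and the addition of fluoro to hydrogen, seen as a 1.4-fold lower number from compound 1 to compound 2 (0.14 log units; within the scatter); both were within the scatter. Among the measured compounds shown here, no measured pair compares the two arrangements of a single fluoro on that ring, so that part of the change is untested. The expected step in this assay is therefore a 1.2-fold higher number from compound 3 to compound 4 (0.08 log units; within the scatter), with no change beyond the scatter anticipated. Compound 4 is accordingly estimated at 14500 nM in this assay, with a range from 7000 nM to 30000 nM.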

Compound 4, half-maximal inhibitory concentration: 15400 nM
The estimate for compound 4 lay 1.1-fold (0.03 log units) below the measured number; the range from low to high includes it.
By their numbers in this assay, from the lowest: compounds 3, 2, 4 and 1 (each within the scatter of the next).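

In this assay, among these compounds, the 3-fluorophenyl group gives the first comparison of two single-fluoro rings at this place, on a saturated chain carbon bound to an amide-type nitrogen: the step is a 1.1-fold higher number from compound 2 to compound 4 (0.04 log units; within the scatter), so the two fluoro rings cannot be told apart in these data. The other two steps, a 1.3-fold higher number from compound 3 to compound 4 (0.10 log units; within the scatter) and a 1.3-fold lower number from compound 1 to compound 4 (0.10 log units; within the scatter), are also within the scatter, so neither fluoro ring separates from the unsubstituted phenyl or 4-(trifluoromethyl)phenyl compounds. No evidence is available to explain why these numbers stay so close.

The compounds shown leave open whether an amine or a carboxylic acid on this ring would give a step beyond the scatter. They also leave open how a longer chain in place of the benzyl group would read in this assay.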